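The source may hold more compounds than are shown below. What is called first, only, known or untested is meant among the compounds shown, and "the series" means these compounds.

Working notes on the series, following the step from compound 1 to compound 3.

Of the compounds shown here, two of the shared core have been measured so far. Compound 1, `C=CCn1c(=O)n([C@@H]2O[C@H](CO)[C@H]3OC(C)(CCC(=O)O)O[C@H]32)c2nc(N)nc(O)c21`, and compound 2, `CCCn1c(=O)n(C2CCC(CO)O2)c2nc(NC(=O)C(C)(C)C)nc(O)c21`, were tested in a functional assay on YAC-1 cells (Mus musculus); a higher number here means a larger maximal response, a lower number a smaller maximal response. In this assay compound 1 gives 0%, and in the same assay compound 2 gives 0%. Compound 1 thus stands level with compound 2 at the digits reported, within the scatter, and no step beyond the scatter is present anywhere in the measured set.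

Compound 3, `C=CCn1c(=O)n([C@@H]2O[C@H](CO)[C@H]3OC(C)(CCC(=O)OCC)O[C@H]32)c2nc(N)nc(O)c21`, has not yet been measured. Relative to compound 1 it carries ethyl in place of hydrogen on an oxygen next to a carbonyl group, so that the carboxy end becomes ethoxycarbonyl. Since compound 1 gives 0% and compound 2 gives 0%, no change beyond the scatter is expected for the step of no change at the digits printed from compound 1 to compound 3 (within the scatter). For compound 3 in this assay the expected value is 0%, within the range 0% to 10%.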

Compound 3, largest response reached (reported as maximal response), in percent of the reference or control that the assay uses: 19%
For compound 3 the middle estimate is 19 percentage points below the measured one; the whole stated range lies below it.
By their numbers in this assay, from the lowest: compounds 1 and 2 (each within the scatter of the next); then compound 3.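

In this assay, ethyl in place of hydrogen on an oxygen next to a carbonyl group, which turns carboxy into ethoxycarbonyl, gives a number 19 percentage points higher from compound 1 to compound 3 (beyond the scatter). Among the compounds shown here, this is the first step beyond the scatter, and it shows that a change at this position alone can move the maximal response, which the earlier compounds could not show. Nothing among the data shown bears on the reason for this step.

Still open, as far as these compounds go, is whether the response follows the group on that oxygen: methyl or a longer chain such as butyl would test this, and a primary amide in place of ethoxycarbonyl would test whether an ester is needed at all. Ethoxycarbonyl appears on compound 3 alone, so whether the step carries over to other compounds of the shared core also remains open.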